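Methylphenyl isomer step in the sulfonamide series

The source may hold more compounds than are shown below. What is called first, only, known or untested is meant among the compounds shown, and "the series" means these compounds.

- Compound 1 `O=C(/C=C/c1cccnc1)NCCCCCc1ccc(S(=O)(=O)Nc2ccccc2)cc1` gives 408 nM
- Compound 2 `O=C(/C=C/c1cccnc1)NCCCCCCc1cccc(S(=O)(=O)Nc2ccccc2)c1` gives 2.82 nM
- Compound 3 `Cc1ccc(NS(=O)(=O)c2cccc(CCCCCCNC(=O)/C=C/c3cccnc3)c2)cc1` gives 6.92 nM

All three values come from a functional assay on Huh-7 cells (Homo sapiens) for inhibition, read by CCK-8 assay, with a stated time of 72 h; a higher number here means a weaker inhibitor, a lower number a stronger inhibitor. Compound 3 holds the middle place of the three numbers, with compound 2 lower and compound 1 much higher.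

The next structure is compound 4 `Cc1ccccc1NS(=O)(=O)c1cccc(CCCCCCNC(=O)/C=C/c2cccnc2)c1`, which carries 2-methylphenyl in place of 4-methylphenyl on a sulfonamide nitrogen. The two compounds have the same atoms, joined differently.

Among the compounds with values here, only one measured step bears on this change: a 2.5-fold higher number from compound 2 to compound 3 (0.39 log units; beyond the scatter). That modest step comes from methyl in place of hydrogen on an aromatic carbon. Compound 1 differs from compound 2 in more than one place, so it offers no clean comparison. Within the data shown here, no measured pair shows the effect of moving the methyl, so the direction remains open. The change is expected to produce a step no larger than the modest one seen with compound 3 at 6.92 nM, and perhaps none beyond the scatter. The estimate is a 1.2-fold higher number from compound 3 to compound 4 (0.06 log units; within the scatter).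

In this assay the estimate for compound 4 is 8 nM, expected to fall between 2.5 nM and 25 nM.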

Compound 4, half-maximal inhibitory concentration: 0.525 nM
The estimate for compound 4 lay 15-fold (1.18 log units) above the measured number; the whole stated range lies above it.
By their numbers in this assay, from the lowest: compound 4; then compound 2; then compound 3; then compound 1.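

In this assay, within the data shown here, the place of the methyl matters far more than the single earlier step suggested: 2-methylphenyl in place of 4-methylphenyl on a sulfonamide nitrogen gives a 13-fold lower number from compound 3 to compound 4 (1.12 log units; beyond the scatter) with no change in atoms, only in how they are joined. Methyl in place of hydrogen on an aromatic carbon therefore has no single direction in this short set, since a 2.5-fold higher number from compound 2 to compound 3 (0.39 log units; beyond the scatter) goes up with 4-methylphenyl while a 5.4-fold lower number from compound 2 to compound 4 (0.73 log units; beyond the scatter) goes down with 2-methylphenyl, and each of these steps lies beyond the scatter. No measurement is available here that bears on why the two isomers differ so widely.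

Open, as far as these compounds go, is whether this drop belongs to methyl alone or extends to other groups on the same aromatic carbon, such as chloro, fluoro or methoxy in 2-chlorophenyl, 2-fluorophenyl or 2-methoxyphenyl, and how 3-methylphenyl or 2,6-dimethylphenyl would read against compound 4. Steps involving compound 1 cannot be read, as it differs from the others in more than one place, so the effect of the chain on the 2-methylphenyl series also stays open.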